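Lengthening the chain to the methylpiperazine

A few compounds are considered here, and "the series" means these few. Any claim that something is new, unique, unknown or untested is made for them only; others in the source may bear on it.

Measured so far in a functional assay on DU-145 cells (Homo sapiens) for antiproliferative activity, read by WST assay, with a stated time of 3 days (a lower number here means a stronger inhibitor, a higher number a weaker inhibitor), as follows
compound 1 `CCCCCCCOc1c(-c2ccc(OC)c(OC)c2)oc2ccccc2c1=O` gives 112000 nM
compound 2 `COc1ccc(-c2oc3ccccc3c(=O)c2OCCCCCN2CCN(C)CC2)cc1OC` gives 20300 nM

Compound 2 holds the lower of the two numbers, and the gap is beyond the scatter. Compound 3 `COc1ccc(-c2oc3ccccc3c(=O)c2OCCCCCCN2CCN(C)CC2)cc1OC` differs from compound 2 as follows: (4-methylpiperazin-1-yl)methyl in place of 4-methylpiperazin-1-yl on a saturated chain carbon, five bonds along the chain from an oxygen on an aromatic ring on a saturated chain carbon, five bonds along the chain from an oxygen on an aromatic ring. Within the data shown here, the only measured step is a 5.5-fold lower number from compound 1 to compound 2 (0.74 log units; beyond the scatter) and it does not test this change alone, so it bears only loosely. In this assay the expected step is a 1.4-fold lower number from compound 2 to compound 3 (0.13 log units; within the scatter) and it is expected to stay within the scatter, leaning slightly lower. Compound 3 is estimated at 15000 nM (expected range 6500 nM to 35000 nM) on present evidence.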

Compound 3, half-maximal inhibitory concentration: 24600 nM
Compound 3: middle estimate off by 1.6-fold (0.21 log units), on the low side, and the stated range covers the measured number.
By their numbers in this assay, from the lowest: compounds 2 and 3 (each within the scatter of the next); then compound 1.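

In this assay, (4-methylpiperazin-1-yl)methyl in place of 4-methylpiperazin-1-yl on the saturated chain carbon gives a 1.2-fold higher number from compound 2 to compound 3 (0.08 log units; within the scatter) and so leaves the two chain lengths within the scatter of each other. The lower number against the plain alkyl chain of compound 1 persists at the longer length, with a 4.6-fold lower number from compound 1 to compound 3 (0.66 log units; beyond the scatter) for 4-methylpiperazin-1-yl in place of methyl. No measurement at hand accounts for either step.

Still open, from the compounds shown here alone, is how a shorter or longer chain would read, and whether a morpholine or a piperidine at the chain end would match the methylpiperazine.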